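The source may report more compounds than this note shows. Statements on the series, on what has been measured and on what is new or still open speak of the compounds shown alone.

Measured so far in a functional assay on A549 cells (Homo sapiens) for inhibition, read by MTT assay, with a stated time of 72 h; on this read-out lower numbers stand for stronger inhibition and higher numbers for weaker inhibition:
- compound 1 `O=C(CCC(=O)OCCCCCCSc1ccc([N+](=O)[O-])c2nonc12)Nc1ccccc1F`: 2440 nM
- compound 2 `COc1ccccc1NC(=O)CCC(=O)OCCCCCCSc1ccc([N+](=O)[O-])c2nonc12`: 1870 nM

For the measured compounds named here, compound 2 gives the lowest of the two numbers in this assay, but its only neighbour, compound 1, lies within the scatter of it, so the two are not separated. Going by the values given here, the one step between measured compounds, a 1.3-fold lower number from compound 1 to compound 2 (0.12 log units; within the scatter), exchanged one substituent on the aromatic ring attached to the amide-type nitrogen and moved the number by less than the scatter.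

Compound 3 `COc1ccc(NC(=O)CCC(=O)OCCCCCCSc2ccc([N+](=O)[O-])c3nonc23)cc1` is the next member. It differs from compound 2 as follows: 4-methoxyphenyl in place of 2-methoxyphenyl on an amide-type nitrogen. Among the compounds with values here, no measured pair shifts a group around the same aromatic ring, so the step from compound 1 to compound 2 is the only point of reference, and it bears on compound 3 only in that a change on this ring left the number essentially where it was. On that basis no step beyond the scatter is expected here either, in neither direction, and the expected step of a 1.1-fold higher number from compound 2 to compound 3 (0.03 log units; within the scatter) is taken as flat. Compound 3 is accordingly estimated at 2000 nM in this assay, with a range from 900 nM to 4500 nM.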

Compound 3, half-maximal inhibitory concentration: 6480 nM
Compound 3: the middle estimate sits 3.2-fold (0.51 log units) below what was measured; measured number above the stated range.
By their numbers in this assay, from the lowest: compounds 2 and 1 (each within the scatter of the next); then compound 3.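

In this assay, the substituent's place on the ring now matters as well as its identity: a 3.5-fold higher number from compound 2 to compound 3 (0.54 log units; beyond the scatter) is a modest step beyond the scatter, although compound 2 and compound 3 contain the same atoms, joined differently. The earlier exchange of 2-fluorophenyl for 2-methoxyphenyl on the amide-type nitrogen had stayed within the scatter, so this position had appeared flat, but a 2.7-fold higher number from compound 1 to compound 3 (0.42 log units; beyond the scatter) also lies beyond the scatter and sets compound 3 apart from both earlier compounds. Nothing available bears on what lies behind this shift.

As far as these compounds go, whether moving the substituent has a similar effect with fluoro in place of methoxy remains open, as does how an amine or a carboxylic acid on this ring would read in this assay. From the compounds shown here alone, with a single cell line and a single read-out, it also remains open whether the step between 2-methoxyphenyl and 4-methoxyphenyl carries over to other cells.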